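One Ring Swap on a Shared Core: Compound 2 to Compound 3

The compounds below may be only part of what the source reports. "The series", "measured", "known", "first", "only" and "open" are said of these compounds alone.

Measured compounds:
compound 1, `COc1cc(/C=C/C(=O)c2cccc(-n3cc(-c4ccc(Cl)cc4)[nH]c3=O)c2)cc(OC)c1OC`, 1720 nM
compound 2, `COc1cc(/C=C/C(=O)c2cccc(-n3cc(-c4ccccc4)[nH]c3=O)c2)ccc1O`, 1880 nM

In a functional assay on LOX IMVI cells (Homo sapiens) for inhibition (on this read-out lower numbers stand for stronger inhibition of growth and higher numbers for weaker inhibition of growth), compound 2 and compound 1 give numbers that lie within the scatter of each other, so neither can be set apart from the other on these two results alone. Compound 3 `O=C(/C=C/c1cccc(O)c1)c1cccc(-n2cc(-c3ccccc3)[nH]c2=O)c1` arises from compound 2 by 3-hydroxyphenyl in place of 4-hydroxy-3-methoxyphenyl on a double-bonded chain carbon bound to a double-bonded chain carbon. Among the measured compounds shown here, no step between two measured compounds covers a change of this kind, so there is nothing to anchor its size; the expectation is for a small shift in this assay, if any beyond the scatter. Compound 3 is therefore estimated at 2600 nM, with a range from 1000 nM to 7000 nM. This expected step is a 1.4-fold higher number from compound 2 to compound 3 (0.14 log units; within the scatter).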

Compound 3, concentration for 50% growth inhibition: 1850 nM
The estimate for compound 3 lay 1.4-fold (0.15 log units) above the measured number; low and high end bracket the measured number.
By their numbers in this assay, from the lowest: compounds 1, 3 and 2 (each within the scatter of the next).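

In this assay, putting 3-hydroxyphenyl in place of 4-hydroxy-3-methoxyphenyl on a double-bonded chain carbon bound to a double-bonded chain carbon gives a 1.0-fold lower number from compound 2 to compound 3 (0.01 log units; within the scatter). Among the compounds shown here, this is the first step that isolates a single place, and it shows that the read-out does not separate these two groups at this position. No measured evidence bears on this result. Going by these compounds, it remains open whether an amine or a carboxylic acid on this ring, or a longer chain in its stead, would give a step beyond the scatter.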